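The source may hold more compounds than are shown below. What is called first, only, known or untested is meant among the compounds shown, and "the series" means these compounds.

In a functional assay on HCT-116 cells (Homo sapiens) for antiproliferative activity, read by radiometric assay, with a stated time of 72 h (a higher number here means a weaker inhibitor, a lower number a stronger inhibitor), compound 1 `Cc1ccc(F)c(Nc2ncnc3cc(NC(=O)CCCCCCC(=O)NO)sc23)c1` gives 1330 nM, compound 2 `COc1ccc(Nc2ncnc3cc(NC(=O)CCCCCCC(=O)NO)sc23)c(C)c1` gives 2480 nM and compound 3 `N#Cc1cccc(Nc2ncnc3cc(NC(=O)CCCCCCC(=O)NO)sc23)c1` gives 2090 nM. Compound 3 cannot be separated from either of the other two: the steps of a 1.6-fold higher number from compound 1 to compound 3 (0.20 log units; within the scatter) and a 1.2-fold lower number from compound 2 to compound 3 (0.07 log units; within the scatter) both stay within the scatter, so the three cannot be ranked.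

The compound still unmeasured, compound 4 `CCc1ccc(Nc2ncnc3cc(NC(=O)CCCCCCC(=O)NO)sc23)cc1`, keeps the shared core and alters one group, with 4-ethylphenyl in place of 3-cyanophenyl on a nitrogen on an aromatic ring. The measured steps that bear on this change are exchanges at that same place. Besides the two already given, there is a 1.9-fold higher number from compound 1 to compound 2 (0.27 log units; within the scatter). All three are small, and none leaves the scatter. Among the measured compounds shown here, no measured compound carries 4-ethylphenyl, however, so the evidence is indirect and the range must stay wide.

On this basis, no step beyond the scatter is expected in this assay, and no direction can be favoured. The estimate amounts to an expected 1.2-fold lower number from compound 3 to compound 4 (0.06 log units; within the scatter). The expected value for compound 4 is 1800 nM, with an estimated range from 800 nM to 4000 nM.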

Compound 4, half-maximal inhibitory concentration: 2360 nM
Estimate against measurement, compound 4: 1.3-fold (0.12 log units) below; the measured number falls inside the stated range.
By their numbers in this assay, from the lowest: compounds 1, 3, 4 and 2 (each within the scatter of the next).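

In this assay, 4-ethylphenyl on the nitrogen on the aromatic ring cannot be separated from any of the three earlier groups: the steps (a 1.1-fold higher number from compound 3 to compound 4 (0.05 log units; within the scatter)), (a 1.1-fold lower number from compound 2 to compound 4 (0.02 log units; within the scatter)) and (a 1.8-fold higher number from compound 1 to compound 4 (0.25 log units; within the scatter)) all stay within the scatter. What compound 4 adds is a group of carbon only, with no hydrogen-bond acceptor, in place of the 3-cyanophenyl with its nitrile, and this exchange does not separate the two compounds either, so all four compounds at this place now stand within the scatter of one another. No measurement in hand explains why these exchanges leave the number so little changed.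

As far as these compounds go, all four groups at this place are substituted phenyl rings, so it remains open whether an amine, a carboxylic acid or a longer chain on that ring would give a step beyond the scatter. The rest of the structure is the same in all four compounds, so they say nothing about changes anywhere else.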